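Working notes: from compound 3 to compound 4

The source may report more compounds than this note shows. Statements on the series, on what has been measured and on what is new or still open speak of the compounds shown alone.

Measured in a functional assay on SGC-7901 cells (Homo sapiens) for inhibition, read by MTT assay, with a stated time of 72 h; on this read-out higher numbers stand for weaker inhibition and lower numbers for stronger inhibition:
- compound 1 `Cc1ccc(N2CCCC2)c(C(=O)Nc2ccc(CNC(=O)OCc3cccnc3)cc2)c1`: 65300 nM
- compound 2 `O=C(NCc1ccc(NC(=O)c2cc(-c3ccccc3)ccc2N2CCCC2)cc1)OCc1cccnc1`: > 100000 nM, a limit of the assay and not a number
- compound 3 `O=C(NCc1ccc(NC(=O)c2cc(F)ccc2N2CCCC2)cc1)OCc1cccnc1`: 44800 nM

Compound 1 at 65300 nM and compound 3 at 44800 nM lie within the scatter of each other. Compound 3 stands clear only of compound 2, with an at least 2.2-fold lower number from compound 2 to compound 3 (0.34 log units; beyond the scatter).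

Compound 4 `COc1ccc(N2CCCC2)c(C(=O)Nc2ccc(CNC(=O)OCc3cccnc3)cc2)c1` has methoxy in place of fluoro on an aromatic carbon, meta to a large group and para to a pyrrolidin-1-yl group: methoxy in place of fluoro on an aromatic carbon.

Three measured swaps at this carbon bear on the change. Fluoro in place of methyl gave a 1.5-fold lower number from compound 1 to compound 3 (0.16 log units; within the scatter). Phenyl in place of methyl gave an at least 1.5-fold higher number from compound 1 to compound 2 (0.18 log units; that floor lies within the scatter), a step that ends at a limit. Only the swap between phenyl and fluoro passes the scatter. Methoxy, like fluoro, brings no ring, so the expectation follows the step of a 1.5-fold lower number from compound 1 to compound 3 (0.16 log units; within the scatter) and not the phenyl steps.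

No step beyond the scatter is expected in this assay, and the estimated change is a 1.1-fold higher number from compound 3 to compound 4 (0.05 log units; within the scatter). For compound 4 the estimate is 50000 nM, with an expected range of 22000 nM to 100000 nM.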

Compound 4, half-maximal inhibitory concentration: 47200 nM
Compound 4: middle estimate off by 1.1-fold (0.03 log units), on the high side, and the stated range covers the measured number.
By their numbers in this assay, from the lowest: compounds 3, 4 and 1 (each within the scatter of the next). At a limit, above all of these: compound 2.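

In this assay, among these compounds, methoxy is the first group at this carbon to bring a hydrogen-bond acceptor, yet the result stays within the scatter: a 1.1-fold higher number from compound 3 to compound 4 (0.02 log units; within the scatter), and a 1.4-fold lower number from compound 1 to compound 4 (0.14 log units; within the scatter). Methyl, fluoro and methoxy are therefore not separated at this carbon, whereas phenyl now stands apart from two of these groups, with methoxy adding a second step beyond the scatter: an at least 2.1-fold lower number from compound 2 to compound 4 (0.32 log units; beyond the scatter). The phenyl compound, compound 2, gives a limit of the assay and not a number: the limit of > 100000 nM in this assay, at which 1 of the 4 values shown sits.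

As far as these compounds go, the true size of the phenyl step remains open, since only its floor is known. Also open, from the compounds shown here alone, is whether an amine or a carboxylic acid at this carbon would move the number beyond the scatter from compound 3 or compound 4.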